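A few compounds are considered here, and "the series" means these few. Any claim that something is new, unique, unknown or untested is made for them only; others in the source may bear on it.

Measured so far in a functional assay on A549 cells (Homo sapiens) for cytotoxicity, read by CCK-8 assay, with a stated time of 72 h; a lower number here means a stronger inhibitor, a higher number a weaker inhibitor:
- compound 1, `COc1ccccc1/C=c1/[nH]c(=O)/c(=C\c2ccccc2OC)n(C)c1=O`: 7000 nM
- compound 2, `COc1ccccc1/C=c1\c(=O)[nH]/c(=C/c2cccc(Cl)c2Cl)c(=O)n1C`: 200 nM
- compound 3, `C=CCn1c(=O)/c(=C\c2ccc(F)c(Br)c2)[nH]c(=O)/c1=C\c1ccccc1OC`: "not active" (no number reported)

Compound 1 gives the highest number of the two compounds with a number in this assay. Its nearest neighbour is compound 2, which carries a 2,3-dichlorophenyl in place of the 2-methoxyphenyl on a double-bonded chain carbon; that single change gives a 35-fold lower number from compound 1 to compound 2 (1.54 log units; beyond the scatter). For the measured compounds named here, compound 3 differs from compound 1 in more than one place and is reported without a number, so no step is drawn from it.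

Compound 4, `COc1ccccc1/C=c1/[nH]c(=O)/c(=C\c2ccccc2OC)[nH]c1=O`, is not yet measured. It differs from compound 1 by hydrogen in place of methyl on an aromatic nitrogen. Going by the values given here, none of the measured steps touches this position: the one quantified step concerns the aryl group on the exocyclic chain, not the ring nitrogen, so no measured change bears directly on the step from compound 1 to compound 4. With the shared core unchanged and only a methyl on the ring nitrogen removed, the expected step of no change at the digits printed from compound 1 to compound 4 (within the scatter) is small and within the usual scatter. Compound 4 is therefore estimated at 7000 nM in this assay, with a range from 2500 nM to 20000 nM.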

Compound 4, half-maximal inhibitory concentration: "not active" (no number reported)
No number was reported for compound 4; the estimate stays without a comparison.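

In this assay, for the compounds shown here, compound 4 gives "not active" (no number reported), so no step from compound 1 to compound 4 can be read. The compounds shown leave open how far hydrogen in place of methyl on the aromatic nitrogen shifts the number, and whether this holds with other aryl groups. Nothing available bears on this result.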